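The source may hold more compounds than are shown below. What is called first, only, known or untested is meant among the compounds shown, and "the series" means these compounds.

Working notes on the series. The two measured compounds share one core and differ only in the group on the aromatic carbon that sits para to the large group. Compound 1 `Cn1cc(-c2ccc(CN3CCC(O)(Cn4cnc5c(-c6ccc(CN)cc6)n(C)nc5c4=O)CC3)c(Cl)c2)cn1` carries 1-methyl-1H-pyrazol-4-yl there; in an assay on isolated protein for inhibition of ubiquitin carboxyl-terminal hydrolase 7 (Homo sapiens), with stated times of 30 min and 2 h (on this read-out higher numbers stand for weaker inhibition and lower numbers for stronger inhibition), compound 1 gives 291 nM. For the measured compounds named here, compound 2 `Cn1nc2c(=O)n(CC3(O)CCN(Cc4ccc(C5=CCCC5)cc4Cl)CC3)cnc2c1-c1ccc(CN)cc1` carries cyclopent-1-en-1-yl instead, and in this assay compound 2 gives 76.9 nM, the lowest of the two numbers so far; the step of a 3.8-fold lower number from compound 1 to compound 2 (0.58 log units; beyond the scatter) is the only measured step and is modest.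

Compound 3 `Cn1nc2c(=O)n(CC3(O)CCN(Cc4ccc(-c5cncs5)cc4Cl)CC3)cnc2c1-c1ccc(CN)cc1` is not yet measured. It differs from compound 2 as follows: 1,3-thiazol-5-yl in place of cyclopent-1-en-1-yl on an aromatic carbon. Going by the values given here, the only step that bears on this change is a 3.8-fold lower number from compound 1 to compound 2 (0.58 log units; beyond the scatter), in which a five-membered aromatic ring with hetero atoms gave way to the carbon-only ring; here a five-membered aromatic ring with 2 hetero atoms comes back in its place. The expectation is therefore a step back toward compound 1, of modest size, in this assay.

For compound 3 the expected step is a 2.1-fold higher number from compound 2 to compound 3 (0.32 log units; beyond the scatter), which is estimated to land at 160 nM, with a range of 60 nM to 420 nM.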

Compound 3, half-maximal inhibitory concentration: 117 nM
The estimate for compound 3 lay 1.4-fold (0.14 log units) above the measured number, and the stated range covers the measured number.
By their numbers in this assay, from the lowest: compounds 2 and 3 (each within the scatter of the next); then compound 1.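

In this assay, a 1.5-fold higher number from compound 2 to compound 3 (0.18 log units; within the scatter) shows that at this position, on an aromatic carbon para to a large group, the aromatic 1,3-thiazol-5-yl and the non-aromatic, carbon-only cyclopent-1-en-1-yl cannot be told apart. Aromaticity with hetero atoms therefore does not by itself return the number to that of compound 1: a 2.5-fold lower number from compound 1 to compound 3 (0.40 log units; beyond the scatter) separates two five-membered aromatic rings with hetero atoms, so among these three compounds compound 1 alone stands apart, and the earlier step between the carbon-only ring and 1-methyl-1H-pyrazol-4-yl cannot be read as a general penalty for such rings. No measurement beside these numbers accounts for the difference between the two heteroaromatic groups.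

Still open, on these data alone, is whether that difference follows the methyl group or the ring itself, a question that 1H-pyrazol-4-yl without the methyl, or a methyl-bearing 1,3-thiazol-5-yl, would address. The compounds shown also say nothing about how a saturated cyclopentyl ring, an amine such as morpholin-4-yl or a carboxylic acid would behave at this place.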